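The compounds below may be only part of what the source reports. "The series", "measured", "known", "first", "only" and "open" are said of these compounds alone.

In a functional assay on MDA-MB-435 cells (Homo sapiens) for cytotoxicity, read by MTT assay, with a stated time of 72 h (on this read-out lower numbers stand for stronger inhibition and higher numbers for weaker inhibition), compound 1 `N[C@H]1CC[C@H](Nc2c(C(=O)NCc3ccco3)nc(Br)c3cccnc23)CC1` gives > 10000 nM, which is a limit of the assay and not a number. Within the data shown here, compound 2 `N[C@H]1CC[C@H](Nc2c(C(=O)NCc3ccc(Cl)cc3)nc(Br)c3cccnc23)CC1` gives 1000 nM, the only true number so far in this small set. Compound 3 `N[C@H]1CC[C@H](Nc2c(C(=O)NCc3cccc(C(F)(F)F)c3)nc(Br)c3cccnc23)CC1` keeps the shared core and changes one group: 3-(trifluoromethyl)phenyl in place of 4-chlorophenyl on a saturated chain carbon bound to an amide-type nitrogen. In words, 3-(trifluoromethyl)phenyl stands in place of 4-chlorophenyl on a saturated chain carbon bound to an amide-type nitrogen.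

Among the measured compounds shown here, only one measured step bears on this change. It is an at least 10-fold lower number from compound 1 to compound 2 (1.00 log units; beyond the scatter), made at the same place, where 4-chlorophenyl replaced furan-2-yl. That step brought in a six-membered aromatic ring of carbon only, and compound 3 keeps such a ring. For the measured compounds named here, no measured step compares two groups that both carry this ring, so the size of the new step cannot be read directly from the data. The expectation in this assay is therefore no clear shift in either direction, and the estimate is no change at the digits printed from compound 2 to compound 3 (within the scatter). For compound 3 the expected value is 1000 nM, with an estimated range of 300 nM to 4000 nM.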

Compound 3, half-maximal inhibitory concentration: 4200 nM
Compound 3: middle estimate off by 4.2-fold (0.62 log units), on the low side; the whole stated range lies below it.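

In this assay, among these compounds, this is the first comparison between two groups that both carry a six-membered aromatic ring of carbon only, and it gives a 4.2-fold higher number from compound 2 to compound 3 (0.62 log units; beyond the scatter). At this place, on a saturated chain carbon bound to an amide-type nitrogen, the presence of such a ring therefore does not settle the number on its own, since what the ring carries also counts, although replacing furan-2-yl with 3-(trifluoromethyl)phenyl still gives an at least 2.3-fold lower number from compound 1 to compound 3 (0.37 log units; beyond the scatter). How large that last step really is stays unknown, as the reading for compound 1 is a limit and not a number: the limit of > 10000 nM in this assay, at which 1 of the 3 values shown sits.

The change from 4-chlorophenyl to 3-(trifluoromethyl)phenyl alters both the substituent and its location on the ring, so the compounds shown cannot separate these two effects; 3-chlorophenyl and 4-(trifluoromethyl)phenyl at the same place would pull them apart. On these data alone, it also remains open how a plain phenyl ring, with neither chlorine nor trifluoromethyl, would read here, and so whether either substituent helps at all.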